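The compounds below may be only part of what the source reports. "The series", "measured", "known", "first", "only" and "open" are said of these compounds alone.

Working notes on a small series of thiosemicarbazide-type compounds.

Compound 3 `Cc1ccnc(/C(N)=N/NC(=S)N2CCSCC2)c1` and compound 1 `Cc1ccnc(/C(N)=N/NC(=S)N2CCOCC2)c1` share one core. In a functional assay on A-431 cells (Homo sapiens) for cytotoxicity, read by MTT assay, with a stated time of 72 h, tested at 3 uM (a lower number here means less inhibition of growth, a higher number more inhibition of growth at the concentration tested), compound 3 gives 34.7%, and compound 1 gives 35.5%. The two differ by morpholin-4-yl in place of thiomorpholin-4-yl on a thiocarbonyl carbon, and the step of a number 0.8 percentage points higher from compound 3 to compound 1 (within the scatter) is small.

Compound 2 `Cc1cccc(/C(N)=N/NC(=S)N2CCSCC2)n1` carries a different core; the difference between the core of compound 2 and the core of compound 3 is not broken down here. In this assay compound 2 gives 51.7%, the highest number of the three measured compounds, beyond the scatter from both compound 1 and compound 3.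

Compound 4 `Cc1cccc(/C(N)=N/NC(=S)N2CCOCC2)n1` has not been measured. It differs from compound 2 by morpholin-4-yl in place of thiomorpholin-4-yl on a thiocarbonyl carbon. The place lines for this change and for the change from compound 3 to compound 1 read the same word for word, so it is the same change, made once on each core. On the core of compound 3 the change produced only a number 0.8 percentage points higher from compound 3 to compound 1 (within the scatter), a step within the scatter. Among the measured compounds shown here, the single precedent rests on one pair only; no compound speaks against it, but none confirms it either.

The step from compound 2 to compound 4 in this assay is therefore expected to be a number 0.3 percentage points higher from compound 2 to compound 4 (within the scatter), about as small as the step from compound 3 to compound 1. Compound 4 is estimated to give 52% in this assay, with a range from 42% to 62% that reflects the usual scatter of this read-out.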

Compound 4, percent growth inhibition at one concentration: 45.8%
Compound 4: middle estimate off by 6.2 percentage points, on the high side; the range from low to high includes it.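

The new step in this assay is a number 5.9 percentage points lower from compound 2 to compound 4 (within the scatter). Set beside the earlier step, morpholin-4-yl in place of thiomorpholin-4-yl on a thiocarbonyl carbon gives no difference between the two cores that can be told from the scatter: the same change on two cores in this assay, a number 0.8 percentage points higher (within the scatter) from compound 3 to compound 1 and a number 5.9 percentage points lower (within the scatter) from compound 2 to compound 4, 6.7 percentage points apart, within the scatter of two such steps. This supports carrying the change from one of these cores to the other as a step within the scatter, but it rests on two pairs in one assay at one concentration, and it shows neither that the two steps are identical nor that the same would hold on any further core.

The compounds shown leave open what other groups on the thiocarbonyl carbon would give, such as a piperidin-1-yl ring, a piperazin-1-yl ring with its second ring nitrogen, or an open-chain dimethylamino group, since only the two six-membered rings named here appear in this position. Equally open, on these data alone, is how the same step would behave on a core carrying an ethyl group or an amine in place of the methyl group.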